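The source may hold more compounds than are shown below. What is called first, only, known or untested is meant among the compounds shown, and "the series" means these compounds.

Measured in an ADME assay on HEK293 cells for displacement of a labelled ligand from 5-hydroxytryptamine receptor 6 (Homo sapiens), read by radioligand binding, with a stated time of 1 h; on this read-out lower numbers stand for stronger inhibition and higher numbers for weaker inhibition:
compound 1, `O=C1c2ccccc2S(=O)(=O)N1CCCCCCN1CCN(c2ccccc2Cl)CC1`, 459 nM
compound 2, `O=C1c2ccccc2S(=O)(=O)N1CCCCCCN1CCN(c2ccccc2F)CC1`, 1620 nM
compound 3, `O=C1c2ccccc2S(=O)(=O)N1CCCCCCN1CCN(c2cccc(C(F)(F)F)c2)CC1`, 52 nM

Compound 1 holds the second highest number of the three, with compound 2 nearest and compound 3 furthest from it. Compound 4, `O=C1c2ccccc2S(=O)(=O)N1CCCCCCN1CCN(c2ccccc2)CC1`, differs from compound 1 in one place: hydrogen in place of chloro on an aromatic carbon. The step that bears most closely on this change is a 3.5-fold higher number from compound 1 to compound 2 (0.55 log units; beyond the scatter), where fluoro replaced chloro at the same aromatic carbon and the number rose. Taking the halogen away altogether continues along that line, so a modest rise in this assay is expected, in the same direction as that step and of a similar size. Compound 4 is therefore expected to give 1300 nM, with a range of 500 nM to 3500 nM, an expected step of a 2.8-fold higher number from compound 1 to compound 4 (0.45 log units; beyond the scatter).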

Compound 4, inhibition constant: 971 nM
Compound 4: the middle estimate sits 1.3-fold (0.13 log units) above what was measured, and the stated range covers the measured number.
By their numbers in this assay, from the lowest: compound 3; then compound 1; then compounds 4 and 2 (each within the scatter of the next).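

In this assay, chloro on this aromatic carbon, ortho to a large group, gives a lower number than hydrogen (a 2.1-fold higher number from compound 1 to compound 4 (0.33 log units; beyond the scatter)), so the chloro substituent carries a modest gain over the plain phenyl. Fluoro at the same carbon cannot be told apart from hydrogen (a 1.7-fold lower number from compound 2 to compound 4 (0.22 log units; within the scatter)). With phenyl as the reference, 3-(trifluoromethyl)phenyl gives the largest of these steps (a 19-fold higher number from compound 3 to compound 4 (1.27 log units; beyond the scatter)).

Still open, going by these compounds, is how bromo, methyl or methoxy on this aromatic carbon would compare with chloro. Nothing available bears on the cause of these steps.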